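A Smaller Chain on the Core and Microsomal Half-life

This account rests on a few compounds, and the source may have more. Where it says the series, first, only, none or still open, it means among the compounds named here.

Compounds measured so far:
- compound 1, `CN(c1ccc2c(c1)S(=O)(=O)N=C(c1c(O)c(-c3cccs3)nn(CCC(C)(C)C)c1=O)N2)S(C)(=O)=O`, half-life 0.112 h
- compound 2, `CC(C)=Cc1nn(CCC(C)(C)C)c(=O)c(C2=NS(=O)(=O)c3cc(NS(C)(=O)=O)ccc3N2)c1O`, half-life 0.283 h

Both compounds were tested in an in vitro ADME assay on microsomes from liver (Macaca mulatta) for metabolic stability, tested at 5 uM; a lower number here means that the compound disappears faster, a higher number that the compound lasts longer. Compound 1 gives 0.112 h and stands lowest of the two numbers; compound 2, which gives 0.283 h, lies above it by a gap beyond the usual scatter of such measurements. Going by the values given here, the two differ in several places at once, so no single structural step between them can be read off.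

Compound 3, `CC(C)CCn1nc(-c2cccs2)c(O)c(C2=NS(=O)(=O)c3cc(N(C)S(C)(=O)=O)ccc3N2)c1=O`, has not yet been measured in this assay. It differs from compound 1 in one place: hydrogen in place of methyl on a saturated chain carbon bound to three saturated chain carbons. The change is small, and nothing in the measured pair shows how such a cut in a saturated chain moves the half-life.

Among the compounds with values here, with no measured step of this kind to lean on, the step of a 1.1-fold lower number from compound 1 to compound 3 (0.05 log units; within the scatter) is expected to stay within the scatter, in either direction. Compound 3 is therefore estimated at 0.1 h, with a likely range from 0.04 h to 0.25 h.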

Compound 3, half-life in the Macaca mulatta assay: 0.167 h
The estimate for compound 3 lay 1.7-fold (0.22 log units) below the measured number; the range from low to high includes it.
By their numbers in the Macaca mulatta assay, from the lowest: compounds 1, 3 and 2 (each within the scatter of the next, the first and the last beyond it).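

Going by these compounds alone, in the Macaca mulatta assay, the cut from 3,3-dimethylbutyl to isopentyl gives the first measured step at this position, a 1.5-fold higher number from compound 1 to compound 3 (0.17 log units; within the scatter), so this one methyl can go from the saturated chain carbon bound to three saturated chain carbons without the half-life moving beyond the scatter. In a physicochemical assay for solubility, at pH 7.4 (on this read-out higher numbers stand for higher solubility and lower numbers for lower solubility), compound 1 gives > 100000 nM, which is a limit of the assay and not a number. In the physicochemical assay compound 3 gives > 100000 nM, also a limit of the assay, so the solubility step between the two chains cannot be read: the limit of > 100000 nM in the physicochemical assay, at which 2 of the 2 values shown sit.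

Still open, from the compounds shown here alone, is whether a larger change at this place, such as a longer chain or a chain ending in an amine or a carboxylic acid, would shift the number in the Macaca mulatta assay beyond the scatter. Compound 2 differs from compound 1 in several places at once, so its half-life cannot show what the chain alone contributes.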